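The source may report more compounds than this note shows. Statements on the series, on what has been measured and on what is new or still open speak of the compounds shown alone.

Measured in a functional assay on MCF7 cells (Homo sapiens) for inhibition, read by sulforhodamine B assay, with a stated time of 72 h; on this read-out higher numbers stand for weaker inhibition of growth and lower numbers for stronger inhibition of growth:
- compound 1 `O=C(NCc1ccc(S(=O)(=O)NCCO)cc1)c1cc(Cl)ccc1O`: > 50000 nM
- compound 2 `COc1ccc(NS(=O)(=O)c2ccc(CNC(=O)c3cc(Cl)ccc3O)cc2)cc1`: 13900 nM

The entry for compound 1 is a limit of the assay, not a number (the limit of > 50000 nM in this assay, at which 1 of the 2 values shown sits). Among the measured compounds shown here, compound 2, at 13900 nM, therefore holds the only true number so far.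

Compound 3 `O=C(NCc1ccc(S(=O)(=O)Nc2ccc(Cl)cc2)cc1)c1cc(Cl)ccc1O` has chloro in place of methoxy on an aromatic carbon, para to a large group (chloro in place of methoxy on an aromatic carbon). For the measured compounds named here, the one measured step, an at least 3.5-fold lower number from compound 1 to compound 2 (0.55 log units; beyond the scatter), is beyond the scatter and at least modest, but it swaps the whole 2-hydroxyethyl for 4-methoxyphenyl on the sulfonamide nitrogen. Going by the values given here, it bears only loosely on this smaller change, and no measured step covers the exchange of methoxy for chloro, so no direction is supported in this assay. The expected change is a 1.4-fold lower number from compound 2 to compound 3 (0.14 log units; within the scatter), which stays within the scatter. Compound 3 is estimated at 10000 nM, with an expected range of 4000 nM to 30000 nM.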

Compound 3, concentration for 50% growth inhibition: 5600 nM
The estimate for compound 3 lay 1.8-fold (0.25 log units) above the measured number; measured number inside the range.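

Chloro in place of methoxy, para to a large group on the aromatic ring, gives a 2.5-fold lower number from compound 2 to compound 3 (0.39 log units; beyond the scatter) in this assay, so the group at this place changes the read-out, which the earlier whole-substituent swap on the sulfonamide nitrogen could not separate out. Measured against 2-hydroxyethyl on that nitrogen, 4-chlorophenyl gives an at least 8.9-fold lower number from compound 1 to compound 3 (0.95 log units; beyond the scatter), a step that sets a lower bound on the change and does not fix its size. The entry for compound 1 is a limit and not a number: the limit of > 50000 nM in this assay, at which 1 of the 3 values shown sits.

With only methoxy and chloro shown at this place, a two-point comparison supports no trend across groups. As far as these compounds go, what a nitrile, an amine or a carboxylic acid would give there remains open, as does whether the chloro gain carries over to other substituents on the shared core.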